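The source may report more compounds than this note shows. Statements on the series, on what has been measured and on what is new or still open speak of the compounds shown alone.

The two measured compounds differ at a single aromatic carbon. In an ADME assay on microsomes from liver (Homo sapiens) for metabolic stability, using NADPH, with a stated time of 40 min, tested at 2 uM (a lower number here means that the compound disappears faster, a higher number that the compound lasts longer), compound 1 `Cc1cccc2c(-c3ccc4cccc(F)c4n3)c[nH]c12` gives 0.983 h as its half-life, while compound 2 `Cc1cccc2c(-c3ccc4ccccc4n3)c[nH]c12` gives 0.35 h and so holds the lower of the two numbers. Compound 3 `Cc1cc(C)c2[nH]cc(-c3ccc4ccccc4n3)c2c1` departs from compound 2 by one change, methyl in place of hydrogen on an aromatic carbon, and the new methyl stands meta to the methyl group already present. For the measured compounds named here, only one measured step is available, a 2.8-fold lower number from compound 1 to compound 2 (0.45 log units; beyond the scatter) and it is the exchange of fluoro for hydrogen on an aromatic carbon. It therefore concerns another group at another carbon and bears on the new change only loosely. Going by the values given here, no measured step shows what a methyl in this place does, so no direction can be drawn from the data, and no shift beyond the scatter is expected in this assay for this change. The estimate accordingly means an expected no change at the digits printed from compound 2 to compound 3 (within the scatter) in this half-life. For compound 3 the estimated half-life is 0.35 h with 0.16 h to 0.8 h as the expected range.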

Compound 3, half-life: 1.57 h
Estimate against measurement, compound 3: 4.5-fold (0.65 log units) below; measured number outside the range, above it.
By their numbers in this assay, from the lowest: compound 2; then compounds 1 and 3 (each within the scatter of the next).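

In this assay the added methyl gives a 4.5-fold higher number from compound 2 to compound 3 (0.65 log units; beyond the scatter), which shows that this aromatic carbon, meta to a methyl group and para to a fused ring, is a place where a single added carbon moves the half-life beyond the scatter. The earlier step, a 2.8-fold lower number from compound 1 to compound 2 (0.45 log units; beyond the scatter), concerned fluoro at another carbon, so the half-life of compound 2 is now seen to respond at a second place, and in each case the compound with hydrogen in that place holds the lower number. Nothing measured here accounts for the size or direction of the methyl step, so the result stands as an observation only.

The compounds shown carry only methyl at this carbon, so it remains open whether a chloro, a methoxy or a longer chain such as ethyl would move the half-life in the same direction or by a similar amount. Going by these compounds, it also remains open whether this methyl and the fluoro of compound 1, placed together in one molecule, would add up or would overlap in their effect on the half-life.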